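Compound 3 to compound 4: a carbonyl substituent swap

This account rests on a few compounds, and the source may have more. Where it says the series, first, only, none or still open, it means among the compounds named here.

Within the data shown here, in a functional assay on HCT-116 cells (Homo sapiens) for cytotoxicity, read by sulforhodamine B assay, with a stated time of 48 h (a lower number here means a stronger inhibitor, a higher number a weaker inhibitor), compound 3 (`CC(=O)n1nc(NC(=O)c2ccccc2)c2c1CN(C(=O)c1ccc([N+](=O)[O-])cc1)C2`) gives 16200 nM and sits level with compound 2 (`CC(=O)n1nc(NC(=O)c2ccccc2)c2c1CN(C(=O)c1cccc([N+](=O)[O-])c1)C2`) at 17300 nM and compound 1 (`CC(=O)n1nc(NC(=O)c2ccccc2)c2c1CN(C(=O)C1CCC(C)CC1)C2`) at 12200 nM on the numbers so far. Compound 4 (`CC(=O)n1nc(NC(=O)c2ccccc2)c2c1CN(C(=O)N(C)C)C2`) differs from compound 3 thus: dimethylamino in place of 4-nitrophenyl on a carbonyl carbon with dimethylamino in place of 4-nitrophenyl on a carbonyl carbon whose other neighbours are an amide-type nitrogen in a ring.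

Three measured steps at this same place bear on the change: a 1.4-fold higher number from compound 1 to compound 2 (0.15 log units; within the scatter) and a 1.3-fold higher number from compound 1 to compound 3 (0.12 log units; within the scatter) and a 1.1-fold lower number from compound 2 to compound 3 (0.03 log units; within the scatter) in turn. None of them leaves the scatter. Among the measured compounds shown here, all three exchange one group with a ring for another, and no measured compound has a group without a ring at this place, so the expectation remains uncertain. Expected in this assay is a 1.1-fold lower number from compound 3 to compound 4 (0.03 log units; within the scatter) and so no step beyond the scatter. The estimate for compound 4 is 15000 nM with an expected range from 7000 nM to 32000 nM for this measurement.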

Compound 4, half-maximal inhibitory concentration: 70300 nM
Estimate against measurement, compound 4: 4.7-fold (0.67 log units) below; the measured number lies above the stated range.
By their numbers in this assay, from the lowest: compounds 1, 3 and 2 (each within the scatter of the next); then compound 4.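

In this assay the swap to dimethylamino, the only group shown without a ring on this carbonyl carbon, gives steps beyond the scatter against all three ring-bearing compounds: a 4.3-fold higher number from compound 3 to compound 4 (0.64 log units; beyond the scatter) and a 4.1-fold higher number from compound 2 to compound 4 (0.61 log units; beyond the scatter) and a 5.8-fold higher number from compound 1 to compound 4 (0.76 log units; beyond the scatter) all run the same way. The place therefore does respond to its substituent, although 4-nitrophenyl, 3-nitrophenyl and 4-methylcyclohexyl could not be told apart there, and compound 4 is the weakest of the four. No measurement at hand accounts for this loss.

Dimethylamino differs from the other groups both in lacking a ring and in being smaller, so these compounds cannot separate the two changes. From the compounds shown here alone, it remains open how a piperidine or a diethylamino group on the same carbonyl carbon would read, which would test the ring and the size apart.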